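This account rests on a few compounds, and the source may have more. Where it says the series, first, only, none or still open, it means among the compounds named here.

In an ADME assay on HeLa cells (Homo sapiens) for cytotoxicity, read by resazurin assay, with a stated time of 65 h (on this read-out lower numbers stand for an effect already at smaller amounts and higher numbers for an effect only at larger amounts of compound), compound 1 (`O=C(NC1CCCCC1)c1ccc([N+](=O)[O-])o1`) gives only a limit (> 20000 nM). Compound 2 (`COC(=O)c1ccc(NC(=O)c2ccc([N+](=O)[O-])o2)cc1`) also gives only a limit (> 20000 nM) and has no number of its own. Compound 3 (`O=C(Nc1cc(C(F)(F)F)cc(C(F)(F)F)c1)c1ccc([N+](=O)[O-])o1`) likewise gives only a limit (> 10000 nM). Compound 4 (`C=CCOc1ccc(NC(=O)c2ccc([N+](=O)[O-])o2)cc1`) carries allyloxy in place of methoxycarbonyl on an aromatic carbon, para to a large group (allyloxy in place of methoxycarbonyl on an aromatic carbon). No measured step sizes this change, so the expectation rests on compound 2 alone, which stands at a limit (> 20000 nM): no step beyond the scatter and no clear direction. The expected step is small (an at least 1.1-fold lower number from compound 2 to compound 4 (0.07 log units; that floor lies within the scatter)). For compound 4 the estimate is 17000 nM with an expected range from 6000 nM to 30000 nM and another limit is likely.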

Compound 4, half-maximal effective concentration: > 20000 nM
Compound 4: only a limit was reported; the forecaster's own chance of this, stated with the estimate: 70%; at least 1.1-fold (0.07 log units) between middle value and limit.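

Compound 2 and compound 4 both stand only as limits, so no step can be read for allyloxy in place of methoxycarbonyl: the limit of > 20000 nM in this assay, at which 3 of the 4 values shown sit.

The compounds shown leave open whether any change to this series gives a measurable value.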